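The compounds below may be only part of what the source reports. "The series", "measured", "known", "first", "only" and "open" are said of these compounds alone.

Compound 1 `COc1ccc(C(=O)/C=C/c2ccc(N(C)C)cc2)c2c1C=CC(C)(C)O2` is the reference point. In a functional assay on HCT-116 cells (Homo sapiens) for antiproliferative activity, read by MTT assay, with a stated time of 24 h (a higher number here means a weaker inhibitor, a lower number a stronger inhibitor), compound 1 gives 1920 nM, the highest of the two plain numbers shown. Its nearest neighbour is compound 2 `CCN(CC)c1ccc(/C=C/C(=O)c2ccc(OC)c3c2OC(C)(C)C=C3)cc1`, which in this assay gives 620 nM; the change of diethylamino in place of dimethylamino on an aromatic carbon brings a 3.1-fold lower number from compound 1 to compound 2 (0.49 log units; beyond the scatter). Compound 3 `COc1ccc(C(=O)/C=C/c2ccc(C(F)(F)F)cc2)c2c1C=CC(C)(C)O2` reaches only a limit of this assay, > 10000 nM, at the limit of > 10000 nM in this assay, at which 1 of the 3 values shown sits. Putting trifluoromethyl in place of the dimethylamino thus gives an at least 5.2-fold higher number from compound 1 to compound 3 (0.71 log units; beyond the scatter), and the corresponding change from the diethylamino gives an at least 16-fold higher number from compound 2 to compound 3 (1.20 log units; beyond the scatter).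

Compound 4 `COc1ccc(C(=O)/C=C/c2ccccc2Cl)c2c1C=CC(C)(C)O2` differs from compound 1 by 2-chlorophenyl in place of 4-(dimethylamino)phenyl on a double-bonded chain carbon bound to a double-bonded chain carbon. Within the data shown here, the steps that bear on this change are the two in which the amino group is lost, both of them rises of at least modest to large size in this assay. Compound 4 is therefore expected to show a rise, a 3.4-fold higher number from compound 1 to compound 4 (0.53 log units; beyond the scatter), with a fair chance that only a limit is reported. The estimate for compound 4 in this assay is 6500 nM, within a range of 2500 nM to 20000 nM.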

Compound 4, half-maximal inhibitory concentration: > 10000 nM
Compound 4: only a limit was reported (the forecaster's own chance of this, stated with the estimate: 40%); middle value at least 1.5-fold (0.18 log units) from the limit.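

In this assay compound 4 gives > 10000 nM, which is a limit of the assay and not a number. Exchanging the whole 4-(dimethylamino)phenyl for 2-chlorophenyl brings an at least 5.2-fold higher number from compound 1 to compound 4 (0.71 log units; beyond the scatter), so the loss seen earlier with trifluoromethyl is not confined to that one group, and a second ring without an amino group also fails to give a plain number. Of the four compounds, only compounds 1 and 2, which carry an amino group, give plain numbers, while compounds 3 and 4 share one limit: the limit of > 10000 nM in this assay, at which 2 of the 4 values shown sit.

That shared limit puts no order on compounds 3 and 4, and compound 4 alone cannot separate the loss of the amino group from the arrival of the chlorine. On these data alone, whether a dipropylamino group or a pyrrolidine ring in place of the dimethylamino would carry the fall in number from compound 1 to compound 2 any further remains open.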